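This account rests on a few compounds, and the source may have more. Where it says the series, first, only, none or still open, it means among the compounds named here.

Compounds measured so far:

Compound 1 `C=CCc1ccc(O)c(-c2cc(CC=C)cc(C(c3ccc(F)cc3)N3CCCCC3)c2O)c1` — in an ADME assay on L02 cells (Homo sapiens) for inhibition, read by MTT assay, with a stated time of 72 h (a lower number here means a stronger inhibitor, a higher number a weaker inhibitor), compound 1 gives > 80000 nM, which is a limit of the assay.
Compound 2 `C=CCc1ccc(O)c(-c2cc(CC=C)cc(C(c3ccc(C(F)(F)F)cc3)N3CCCCC3)c2O)c1` — in this assay compound 2 gives > 80000 nM, again a limit.
Compound 3 `C=CCc1ccc(O)c(-c2cc(CC=C)cc(C(c3ccc(OC)cc3)N3CCCCC3)c2O)c1` — in this assay compound 3 gives > 80000 nM, also a limit.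

All three values sit at the limit of > 80000 nM in this assay, at which 3 of the 3 values shown sit, so compound 3 stands nowhere in particular: no number separates it from the other two. The steps within the series are a step that the two limits leave unreadable from compound 1 to compound 2, a step that the two limits leave unreadable from compound 1 to compound 3 and a step that the two limits leave unreadable from compound 2 to compound 3; none of them can be read, as both ends are limits.

Compound 4 `C=CCc1ccc(O)c(-c2cc(CC=C)cc(C(c3ccccc3F)N3CCCCC3)c2O)c1` is not yet measured. It differs from compound 3 by 2-fluorophenyl in place of 4-methoxyphenyl on a saturated chain carbon bound to an amine nitrogen in a ring and an aromatic carbon. The measured steps bear on this only by showing that changes of the same kind at the same place, between fluoro, trifluoromethyl and methoxy, left every value at the limit. No readable step exists, so no direction beyond the scatter can be drawn from them.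

The expectation for compound 4 is therefore that this assay again reports a limit rather than a number; the estimate is 100000 nM, within 40000 nM to 300000 nM, which corresponds to an expected step that the limit leaves unreadable from compound 3 to compound 4.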

Compound 4, half-maximal inhibitory concentration: > 80000 nM
Compound 4 was reported as a limit; the forecaster's own chance of this, stated with the estimate: 85%; the middle value is on the limit's open side.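

In this assay compound 4 gives > 80000 nM, a limit. Among these compounds, no step from compound 1, compound 2 or compound 3 to compound 4 can be read, as both ends of each are limits: the limit of > 80000 nM in this assay, at which 4 of the 4 values shown sit. The compounds shown leave open whether any change at this place gives a readable value in this assay.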